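This account rests on a few compounds, and the source may have more. Where it says the series, first, only, none or still open, it means among the compounds named here.

Among the compounds with values here, in a functional assay on HeLa cells (Homo sapiens) for antiproliferative activity, read by MTT assay, with a stated time of 72 h (a lower number here means a stronger inhibitor, a higher number a weaker inhibitor), two compounds sharing one core have numbers so far. There, compound 1 `Nc1nc(N)c2cc(CSC(=S)N3CCN(c4ccc(Cl)c(Cl)c4)CC3)ccc2n1` gives 3060 nM. Compound 2 `Nc1nc(N)c2cc(CSC(=S)N3CCN(c4ccc(F)cc4F)CC3)ccc2n1` gives 3800 nM, which places it level with compound 1 within the usual scatter of such measurements. Within the data shown here, the one measured step is a 1.2-fold higher number from compound 1 to compound 2 (0.09 log units; within the scatter), where 2,4-difluorophenyl takes the place of 3,4-dichlorophenyl on an amine nitrogen in a ring.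

Compound 3 `Nc1nc(N)c2cc(CSC(=S)N3CCN(c4ncccn4)CC3)ccc2n1` keeps the same core and changes that same place again, with pyrimidin-2-yl in place of 2,4-difluorophenyl on an amine nitrogen in a ring. Among the measured compounds shown here, this change reaches further than the measured one, since the entering aromatic ring is no longer of carbon only, and no measured compound carries such a ring. The small step of a 1.2-fold higher number from compound 1 to compound 2 (0.09 log units; within the scatter) is therefore only a weak guide, and it points to no direction. The expectation is no clear change beyond the scatter, though with real uncertainty. The expected step is a 1.2-fold higher number from compound 2 to compound 3 (0.07 log units; within the scatter). For compound 3 the estimate is 4500 nM, with an expected range from 1800 nM to 11000 nM.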

Compound 3, half-maximal inhibitory concentration: 4360 nM
Estimate against measurement, compound 3: 1.0-fold (0.01 log units) above, within the range that was stated.
By their numbers in this assay, from the lowest: compounds 1, 2 and 3 (each within the scatter of the next).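

Up to this point, the groups on this amine nitrogen in a ring were 3,4-dichlorophenyl and 2,4-difluorophenyl, both aromatic rings of carbon only that carry halogens. Pyrimidin-2-yl brings a six-membered aromatic ring with 2 hetero atoms and 2 hydrogen-bond acceptors, yet this assay shows a 1.1-fold higher number from compound 2 to compound 3 (0.06 log units; within the scatter) and also a 1.4-fold higher number from compound 1 to compound 3 (0.15 log units; within the scatter). For these three compounds, then, moving from a carbon-only ring with halogens to a ring containing nitrogen leaves the number within the scatter, and no evidence is available to explain this.

Going by these compounds, all three groups at this position are six-membered aromatic rings, so it remains open whether the numbers would stay this close with a group lacking such a ring, such as a methyl, a cyclohexyl or a longer carbon chain ending in a carboxylic acid. On these data alone, it also remains open whether an aromatic ring carrying an amine would give a step beyond the scatter, which would show that this position can change the number at all.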